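A few compounds are considered here, and "the series" means these few. Any claim that something is new, unique, unknown or untested is made for them only; others in the source may bear on it.

Compound 1 `CC(C)C(=O)Nc1c(C(O)(C(F)(F)F)C(F)(F)F)ccc2ccccc12` is the starting point of this pair: in an assay on LtK cells with ATP-sensitive inward rectifier potassium channel 11 (Homo sapiens) as the target (a lower number here means that less compound is needed, a higher number that more compound is needed for the effect), compound 1 gives 6630 nM. Compound 2 `O=C(Nc1c(C(O)(C(F)(F)F)C(F)(F)F)ccc2ccccc12)c1ccccc1Cl` carries a 2-chlorophenyl on the carbonyl carbon instead of the isopropyl, and in this assay compound 2 gives 2040 nM. That single step is a 3.3-fold lower number from compound 1 to compound 2 (0.51 log units; beyond the scatter). On the numbers shown, compound 2 stands at the lowest value of the two, with compound 1 as its only neighbour at a higher number.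

Compound 3 `O=C(Nc1c(C(O)(C(F)(F)F)C(F)(F)F)ccc2ccccc12)c1ccc(Cl)c(Cl)c1` is the next step, and its difference from compound 2 is:

3,4-dichlorophenyl in place of 2-chlorophenyl on a carbonyl carbon

Within the data shown here, only one measured step exists, and it swaps an isopropyl for an aryl rather than moving chlorine from one place on an aryl to another, so it bears on this step only loosely: it shows that an aryl on the carbonyl carbon is tolerated, and in this assay compound 2 gives 2040 nM. Among the measured compounds shown here, no measured pair tells how the chlorine pattern on that aryl matters. A step of no more than modest size is expected in this assay, in either direction, most likely within the scatter. The step from compound 2 to compound 3 is expected to be a 1.4-fold lower number from compound 2 to compound 3 (0.13 log units; within the scatter). Compound 3 is therefore estimated at 1500 nM, within a range from 500 nM to 5000 nM.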

Compound 3, half-maximal effective concentration: 194 nM
The estimate for compound 3 lay 7.7-fold (0.89 log units) above the measured number; measured number below the stated range.
By their numbers in this assay, from the lowest: compound 3; then compound 2; then compound 1.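

In this assay, the make-up of the aryl on the carbonyl carbon turns out to matter more than the earlier swap of isopropyl for an aryl suggested: the change to 3,4-dichlorophenyl gives an 11-fold lower number from compound 2 to compound 3 (1.02 log units; beyond the scatter), a large step set against the modest 3.3-fold lower number from compound 1 to compound 2 (0.51 log units; beyond the scatter). Measured against the isopropyl amide, the full change comes to a 34-fold lower number from compound 1 to compound 3 (1.53 log units; beyond the scatter), so this position does more than tolerate an aryl, and among these compounds the choice of chlorine pattern on that aryl accounts for the larger share of the range. No supporting information is available here to account for this result.

The step alters both the number of chlorines and their places at once, and the compounds shown cannot separate these two changes. From the compounds shown here alone, whether a 3-chlorophenyl or a 4-chlorophenyl alone would reach a similar number stays open, as does whether a methoxy or a trifluoromethyl on the ring, or a pyridine ring in place of the phenyl, would serve as well.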